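Swapping dimethylamino for pyrrolidine on a shared saturated core

A few compounds are considered here, and "the series" means these few. Any claim that something is new, unique, unknown or untested is made for them only; others in the source may bear on it.

Three measured compounds share one core and differ only in two attached groups. Compound 1 `CN(C)C12CC(OC(=O)CN3CCCC3)C(C(c3ccccc3)C1)C(c1ccccc1)C2` carries a dimethylamino group on a saturated ring carbon and a pyrrolidin-1-yl group on a saturated chain carbon bound to a carbonyl carbon. In an ADME assay on L6 cells (Rattus norvegicus) for cytotoxicity (a lower number here means a stronger inhibitor, a higher number a weaker inhibitor), compound 1 gives 32700 nM. Compound 2 `O=C(CN1CCCC1)OC1CC2(N3CCCC3)CC(c3ccccc3)C1C(c1ccccc1)C2` differs from compound 1 in one place: pyrrolidin-1-yl in place of dimethylamino on a saturated ring carbon. In this assay compound 2 gives 42900 nM, so that a 1.3-fold higher number from compound 1 to compound 2 (0.12 log units; within the scatter). Compound 3 `CN(C)C12CC(OC(=O)CN3CCC(O)CC3)C(C(c3ccccc3)C1)C(c1ccccc1)C2` keeps the dimethylamino group of compound 1 and differs from it at the other position: 4-hydroxypiperidin-1-yl in place of pyrrolidin-1-yl on a saturated chain carbon bound to a carbonyl carbon. In this assay compound 3 gives 102000 nM, the highest number of the three, and a 3.1-fold higher number from compound 1 to compound 3 (0.49 log units; beyond the scatter).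

Compound 4 `O=C(CN1CCC(O)CC1)OC1CC2(N3CCCC3)CC(c3ccccc3)C1C(c1ccccc1)C2` has not yet been measured. It differs from compound 3 in one place: pyrrolidin-1-yl in place of dimethylamino on a saturated ring carbon. Within the data shown here, this is the same kind of change as the one from compound 1 to compound 2, though the surroundings are not identical: in compound 1 the ring atom that bears the ester carries a (((pyrrolidin-1-yl)methyl)carbonyl)oxy group, whereas in compound 3 it carries a (((4-hydroxypiperidin-1-yl)methyl)carbonyl)oxy group. Among the measured compounds shown here, the only precedent is compound 1 to compound 2, and a small step is expected here because a 1.3-fold higher number from compound 1 to compound 2 (0.12 log units; within the scatter). The expected step is a 1.3-fold higher number from compound 3 to compound 4 (0.11 log units; within the scatter). Compound 4 is therefore estimated at 130000 nM in this assay, with a likely range from 60000 nM to 280000 nM.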

Compound 4, half-maximal inhibitory concentration: 93400 nM
Compound 4: the middle estimate sits 1.4-fold (0.14 log units) above what was measured, and the stated range covers the measured number.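

In this assay, the swap of dimethylamino for pyrrolidin-1-yl on the saturated ring carbon again makes no change beyond the scatter, with a 1.1-fold lower number from compound 3 to compound 4 (0.04 log units; within the scatter), so this swap looks equally small whichever ester side group is present: the same change on two cores in this assay, a 1.3-fold higher number (0.12 log units; within the scatter) from compound 1 to compound 2 and a 1.1-fold lower number (0.04 log units; within the scatter) from compound 3 to compound 4, 1.4-fold (0.16 log units) apart, within the scatter of two such steps. The second change, 4-hydroxypiperidin-1-yl in place of pyrrolidin-1-yl on the saturated chain carbon, also carries over, with a 2.2-fold higher number from compound 2 to compound 4 (0.34 log units; beyond the scatter), and its size holds up whichever amine sits on the ring carbon: the same change on two cores in this assay, a 3.1-fold higher number (0.49 log units; beyond the scatter) from compound 1 to compound 3 and a 2.2-fold higher number (0.34 log units; beyond the scatter) from compound 2 to compound 4, 1.4-fold (0.16 log units) apart, within the scatter of two such steps. Together, the four compounds suggest that the two positions act independently of each other in this assay, but each change has been seen only twice, on closely related compounds and in one rat cell line, so this gives no rule for other cores and no explanation of why the numbers move as they do.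

The compounds shown leave open whether a different amine on the saturated ring carbon, such as diethylamino or morpholin-4-yl, would also leave the number within the scatter. They also leave open whether a carboxylic acid in place of the hydroxy group, or a longer chain carrying the 4-hydroxypiperidin-1-yl group, would raise the number further.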